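Swapping the Substituted Phenyl Ring of Compound 2

The source may report more compounds than this note shows. Statements on the series, on what has been measured and on what is new or still open speak of the compounds shown alone.

Compound 2 `CC/C(=C(/c1ccc(/C=C/C(=O)O)cc1)c1cc2ccccc2[nH]1)c1ccc(C(F)(F)F)cc1Cl` gives 27 nM in a functional assay on MCF7 cells (Homo sapiens) for inhibition; a higher number here means a weaker inhibitor, a lower number a stronger inhibitor. Among the measured compounds shown here, the only other measured compound, compound 1 `CC/C(=C(/c1ccc(/C=C/C(=O)O)cc1)c1cc2ccccc2[nH]1)c1ccc(F)cc1Cl`, gives 39 nM, so the two numbers sit within the scatter of each other. That one step, a 1.4-fold lower number from compound 1 to compound 2 (0.16 log units; within the scatter), came from a change on the same ring that is now altered again. Compound 3 `CC/C(=C(/c1ccc(/C=C/C(=O)O)cc1)c1cc2ccccc2[nH]1)c1ccc(Cl)cc1C#N` carries 4-chloro-2-cyanophenyl in place of 2-chloro-4-(trifluoromethyl)phenyl on a double-bonded chain carbon bound to a double-bonded chain carbon and a saturated chain carbon. Because that single step, a 1.4-fold lower number from compound 1 to compound 2 (0.16 log units; within the scatter), was small, a shift within the scatter is expected, a 1.7-fold higher number from compound 2 to compound 3 (0.22 log units; within the scatter). Compound 3 is estimated at 45 nM, with a range from 15 nM to 150 nM.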

Compound 3, half-maximal inhibitory concentration: 14 nM
Estimate against measurement, compound 3: 3.2-fold (0.51 log units) above; measured number below the stated range.
By their numbers in this assay, from the lowest: compounds 3, 2 and 1 (each within the scatter of the next, the first and the last beyond it).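

In this assay, changing the ring on this double-bonded chain carbon now gives a step beyond the scatter, though a modest one (a 2.8-fold lower number from compound 1 to compound 3 (0.44 log units; beyond the scatter)), while the other step stays within it (a 1.9-fold lower number from compound 2 to compound 3 (0.29 log units; within the scatter)). The earlier pair showed no such separation, so the choice of substituents on this ring can move the number, and a ring carrying a nitrile keeps inhibition. Nothing available here explains this shift.

Whether the nitrile or the placement of the chlorine in 4-chloro-2-cyanophenyl accounts for the step stays open. On these data alone, how an amine or a methoxy group on this ring would behave is also open.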